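4-Fluorophenyl for 2,4-dichlorophenyl on two cores

This account rests on a few compounds, and the source may have more. Where it says the series, first, only, none or still open, it means among the compounds named here.

Measured in a functional assay on U-251 cells (Homo sapiens); a higher number here means a weaker inhibitor of growth, a lower number a stronger inhibitor of growth:
compound 1 `O=S(=O)(/C=C/c1ccc(F)cc1)Cc1ccc(Nc2ncnc3ccccc23)cc1`: 10 nM
compound 2 `O=S(=O)(/C=C/c1ccc(Cl)cc1Cl)Cc1ccc(Nc2ncnc3ccccc23)cc1`: 4000 nM
compound 3 `COc1cc2ncnc(Nc3ccc(CS(=O)(=O)/C=C/c4ccc(Cl)cc4Cl)cc3)c2cc1OC`: 13000 nM

Compound 2 and compound 1 share a core and differ in one place, (4-fluorophenyl in place of 2,4-dichlorophenyl on a double-bonded chain carbon bound to a double-bonded chain carbon). Among the measured compounds shown here, this change gave a 400-fold lower number from compound 2 to compound 1 (2.60 log units; beyond the scatter), the one step of its kind measured so far.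

Compound 3 carries the same 2,4-dichlorophenyl group on a different core; the difference between the two cores is not broken down here. In this assay compound 3 gives the highest number of the three, and its value stands well beyond the scatter from compound 2 as well as from compound 1.

Compound 4 `COc1cc2ncnc(Nc3ccc(CS(=O)(=O)/C=C/c4ccc(F)cc4)cc3)c2cc1OC` is compound 3 with the same change applied: 4-fluorophenyl in place of 2,4-dichlorophenyl on a double-bonded chain carbon bound to a double-bonded chain carbon. The place is the same in both pairs, so this is the same change, now on the core of compound 3.

Resting on the precedent of compound 2 to compound 1 with a 400-fold lower number from compound 2 to compound 1 (2.60 log units; beyond the scatter), the step from compound 3 to compound 4 is expected to be large, estimated at a 260-fold lower number from compound 3 to compound 4 (2.41 log units; beyond the scatter), taken somewhat smaller than that precedent: only one example exists and the transfer across cores is untested. Compound 4 is therefore estimated at 50 nM, with a range from 10 nM to 400 nM.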

Compound 4, concentration for 50% growth inhibition: > 100000 nM
Compound 4: a limit, no number; the forecaster's own chance of this, stated with the estimate: 2%; at least 2000-fold (3.30 log units) between middle value and limit.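

The 2,4-dichlorophenyl to 4-fluorophenyl change does not carry over between these two cores in direction: on the core of compound 3 it gives an at least 7.6-fold higher number from compound 3 to compound 4 (0.88 log units; beyond the scatter), whereas on the core of compound 1 it gives a 400-fold lower number from compound 2 to compound 1 (2.60 log units; beyond the scatter). In this assay, on these data alone, compound 4 gives > 100000 nM, which is a limit of the assay and not a number, so the full size of this step stays unknown. The outcome of the change therefore differs with the core in the two pairs available, although these pairs do not show which feature of the cores is responsible for the reversal: the same change on two cores in this assay, a 400-fold lower number (2.60 log units; beyond the scatter) from compound 2 to compound 1 and an at least 7.6-fold higher number (0.88 log units; beyond the scatter) from compound 3 to compound 4, at least 3000-fold (3.48 log units) apart, beyond the scatter of two such steps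

Open, as far as these compounds go, is how an unsubstituted phenyl group in the same place would read on each core, which could help separate the effect of gaining the fluorine from that of losing the two chlorines. Among the compounds shown here, also open is whether a core carrying only one methoxy group would follow the core of compound 1 or that of compound 3.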